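Removing a trifluoromethyl from the amide of compound 2

The source may report more compounds than this note shows. Statements on the series, on what has been measured and on what is new or still open speak of the compounds shown alone.

Compound 2 `COc1cc(-c2nn(-c3cccc(NC(=O)c4cccc(C(F)(F)F)c4)c3)cc2-c2ccncc2)ccc1Cl` gives 27000 nM in a functional assay on NCI-H226 cells (Homo sapiens) for inhibition, read by sulforhodamine B assay, with a stated time of 48 h (on this read-out higher numbers stand for weaker inhibition of growth and lower numbers for stronger inhibition of growth), the highest of the two numbers measured. Compound 3 `O=C(Nc1cccc(-n2cc(-c3ccncc3)c(-c3ccc(Cl)c(O)c3)n2)c1)Nc1cc(C(F)(F)F)cc(C(F)(F)F)c1` gives 6120 nM in this assay. Compound 1 `O=C(Nc1cccc(-n2cc(-c3ccncc3)c(-c3ccc(Cl)c(O)c3)n2)c1)Nc1cccc(C(F)(F)F)c1` reaches only the assay limit of > 32500 nM in this assay. The change to compound 4 `COc1cc(-c2nn(-c3cccc(NC(=O)c4ccccc4)c3)cc2-c2ccncc2)ccc1Cl` is hydrogen in place of trifluoromethyl on an aromatic carbon. Among the compounds with values here, the one measured step in the opposite direction, an at least 5.3-fold lower number from compound 1 to compound 3 (0.72 log units; beyond the scatter), added a trifluoromethyl and lowered the number, though its full size is hidden by the limit of > 32500 nM in this assay, at which 1 of the 3 values shown sits. Taking that step backwards, compound 4 is expected to show a higher number than compound 2, the step from a 2.0-fold higher number from compound 2 to compound 4 (0.31 log units; beyond the scatter) being a modest weakening. Compound 4 is therefore estimated at 55000 nM, with a range from 20000 nM to 150000 nM, and may well fall beyond the limit of this assay.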

Compound 4, concentration for total growth inhibition: > 100000 nM
Compound 4 was reported as a limit; the forecaster's own chance of this, stated with the estimate: 60%; at least 1.8-fold (0.25 log units) between middle value and limit.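

Replacing trifluoromethyl with hydrogen on the benzoyl ring gives an at least 3.7-fold higher number from compound 2 to compound 4 (0.56 log units; beyond the scatter) in this assay, so on this core too the group goes with stronger inhibition of growth. The value of compound 4, > 100000 nM, is a limit of the assay, so the full size of this step stays hidden. The change now points the same way on two cores: the same change on two cores in this assay, an at least 5.3-fold lower number (0.72 log units; beyond the scatter) from compound 1 to compound 3 and an at least 3.7-fold lower number (0.56 log units; beyond the scatter) from compound 4 to compound 2; the limit leaves it open whether they differ

The compounds shown leave open whether a nitrile or an amine at this place would behave more like trifluoromethyl or more like hydrogen. They also leave open whether a second trifluoromethyl would lower the number on the core of compound 2, as it does in compound 3.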